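The compounds below may be only part of what the source reports. "The series", "measured", "known", "first", "only" and "open" are said of these compounds alone.

Of the compounds shown here, two have so far been measured in a functional assay on the whole organism (Ear) for inhibition, with Mus musculus as the target, with a stated time of 30 min, at a dose of 100 mg/kg by the intraperitoneal route; a lower number here means less inhibition, a higher number more inhibition at the dose given (going by the name of the read-out). Compound 1 `Cc1ccc(C(=O)/C=C/c2ccc(/C=N/NC(=N)N)cc2)c(C)c1` gives 64.2%. Compound 2 `O=C(N/N=C/c1ccc(/C=C/C(=O)c2ccccc2Cl)cc1)c1cccc(Cl)c1` gives 43%, the lower of the two numbers, and the gap to compound 1 lies beyond the usual scatter of repeated measurements. Compound 3 `N=C(N)N/N=C/c1ccc(/C=C/C(=O)c2ccccc2Cl)cc1` remains to be measured. It differs from compound 2 in one place: a group of 3 heavy atoms (1 carbon, 2 nitrogen; no ring) in place of a group of 9 heavy atoms (7 carbon, 1 oxygen, 1 chlorine; one six-membered aromatic ring of carbon only), on an amine nitrogen. The group that enters is the same group that compound 1 carries on its own hydrazone nitrogen, so compound 1 serves as the point of comparison for the entering group while compound 2 supplies the rest of the structure. Among the measured compounds shown here, no step between measured compounds isolates this change on an otherwise fixed scaffold; what the two values show is that compound 1, bearing the entering group, gives the higher number and compound 2, bearing the leaving group, the lower. The step of a number 13 percentage points higher from compound 2 to compound 3 (beyond the scatter) is therefore expected to run upward, of a size near the edge of the scatter. Compound 3 is expected to give 56%, with a range from 38% to 74%.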

Compound 3, a percentage reported as inhibition, in the whole organism at one dose (the size of the read-out at that dose, not a potency): 84.1%
Beside the measured number, compound 3's estimate is 28.1 percentage points below it; measured number outside the range, above it.
By their numbers in this assay, from the lowest: compound 2; then compound 1; then compound 3.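

In this assay, among the compounds shown here, the group of 3 heavy atoms (1 carbon, 2 nitrogen; no ring) in place of (3-chlorophenyl)carbonyl on the amine nitrogen gives a number 41.1 percentage points higher from compound 2 to compound 3 (beyond the scatter) and so supplies the first reading of this position with the rest of the structure held fixed: the change at this one place is enough to move the read-out by a large step. With that same group kept, 2-chlorophenyl in place of 2,4-dimethylphenyl on a carbonyl carbon gives a number 19.9 percentage points higher from compound 1 to compound 3 (beyond the scatter) and shows that this second place also moves the read-out, by a step printed as modest. No measurement at hand accounts for either step.

From the compounds shown here alone, whether an acetyl group or a plain methyl on the amine nitrogen would fall nearer compound 2 or compound 3 stays open, and so does the outcome for an unsubstituted phenyl or a 2-fluorophenyl on the carbonyl carbon. All of these readings come from a single dose, so they show the size of the read-out at that dose and leave the potency of compound 3 open.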